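This account rests on a few compounds, and the source may have more. Where it says the series, first, only, none or still open, it means among the compounds named here.

Three esters of the shared core have been measured. Compound 3 `O=C(OC1(C(=O)Nc2ccc([N+](=O)[O-])cc2)CCCCC1)c1ccccc1` carries an unsubstituted phenyl ester, and in an ADME assay on WI-38 cells (Homo sapiens) for inhibition, read by MTT assay, with a stated time of 72 h (on this read-out lower numbers stand for stronger inhibition and higher numbers for weaker inhibition), compound 3 gives 246 nM. Compound 1 `COc1ccc(C(=O)OC2(C(=O)Nc3ccc([N+](=O)[O-])cc3)CCCCC2)cc1` carries a methoxy on that ring, and in this assay compound 1 gives 40 nM. Compound 2 `O=C(OC1(C(=O)Nc2ccc([N+](=O)[O-])cc2)CCCCC1)c1ccc([N+](=O)[O-])cc1` carries a nitro on that ring, and in this assay compound 2 gives 761 nM. Compound 3 therefore stands second highest of the three numbers: there is a 6.2-fold higher number from compound 1 to compound 3 (0.79 log units; beyond the scatter) and there is a 3.1-fold lower number from compound 2 to compound 3 (0.49 log units; beyond the scatter), both beyond the scatter.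

Compound 4 `CC(=O)Oc1ccccc1C(=O)OC1(C(=O)Nc2ccc([N+](=O)[O-])cc2)CCCCC1` differs from compound 3 by acetoxy in place of hydrogen on an aromatic carbon. The two measured steps show that a single group on this ring can move the number in either direction, modestly with the methoxy and more strongly with the nitro. Acetoxy, like methoxy, is joined to the ring through oxygen, but it is a different and larger group, so a smaller shift than the methoxy step seems reasonable. The step from compound 3 to compound 4 is expected to be modest and downward, a 1.6-fold lower number from compound 3 to compound 4 (0.21 log units; within the scatter). Compound 4 is estimated at 150 nM, with a range from 50 nM to 450 nM.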

Compound 4, half-maximal inhibitory concentration: 48.4 nM
Compound 4: middle estimate off by 3.1-fold (0.49 log units), on the high side, outside the stated range (below it).
By their numbers in this assay, from the lowest: compounds 1 and 4 (each within the scatter of the next); then compound 3; then compound 2.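

Acetoxy, ortho to a large group on the ester's aromatic ring, lowers the number well beyond the scatter in this assay, with a 5.1-fold lower number from compound 3 to compound 4 (0.71 log units; beyond the scatter), so methoxy is no longer the only group shown to do this. Replacing 4-methoxyphenyl with 2-acetoxyphenyl leaves the number within the scatter, with a 1.2-fold higher number from compound 1 to compound 4 (0.08 log units; within the scatter), so two different groups, named at different ring positions, reach the same level, while replacing 4-nitrophenyl with 2-acetoxyphenyl gives the largest of the new steps, a 16-fold lower number from compound 2 to compound 4 (1.20 log units; beyond the scatter). Nothing available explains why acetoxy has this effect on the number.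

Compound 4 differs from compounds 1 and 2 in both the group and its position on the ring, so these compounds cannot show how much of the result belongs to acetoxy itself and how much to where it sits. Going by these compounds, a hydroxyl group or a methoxy ortho to the same large group, or acetoxy in the position that methoxy holds in compound 1, would help separate the two, and a longer acyl chain in place of the acetyl part of acetoxy remains open as well.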